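The source may report more compounds than this note shows. Statements on the series, on what has been measured and on what is new or still open speak of the compounds shown alone.

Working notes on an ADME assay on microsomes from liver (Mus musculus) for metabolic stability, read by LC-MS, using NADPH, with a stated time of 10 min, tested at 0.1 uM; a higher number here means faster removal of the compound, a lower number slower removal. Compound 1 `O=C(NCCCCc1ccccc1)c1cccc(C2SCC(=O)N2c2cccc(-c3c[nH]nn3)c2)c1` gives 951 mL.min-1.g-1, compound 2 `O=C(NCCCCc1ccccc1)c1cccc(C2SCC(=O)N2c2ccccn2)c1` gives 644 mL.min-1.g-1 and compound 3 `C#Cc1cccc(N2C(=O)CSC2c2cccc(C(=O)NCCCCc3ccccc3)c2)c1` gives 1900 mL.min-1.g-1. Compound 3 thus sits with compound 1 at the upper end of these numbers and apart from compound 2.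

Compound 4 `CC(F)(F)c1cccc(N2C(=O)CSC2c2cccc(C(=O)NCCCCc3ccccc3)c2)c1` is still unmeasured and differs from compound 3 as follows: 1,1-difluoroethyl in place of ethynyl on an aromatic carbon. In short, this is 1,1-difluoroethyl in place of ethynyl on an aromatic carbon.

Going by the values given here, no measured step brings in 1,1-difluoroethyl, so the evidence is indirect. The closest step also concerns ethynyl on an aromatic carbon: a 2.0-fold higher number from compound 1 to compound 3 (0.30 log units; within the scatter). The step that exchanges the whole group on the amide-type nitrogen in a ring is modest: a 3.0-fold higher number from compound 2 to compound 3 (0.47 log units; beyond the scatter).

On these two steps, no change beyond the scatter is expected in this assay. The expected step is a 1.2-fold lower number from compound 3 to compound 4 (0.07 log units; within the scatter). Compound 4 is estimated at 1600 mL.min-1.g-1, with an expected range from 750 mL.min-1.g-1 to 3200 mL.min-1.g-1.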

Compound 4, intrinsic clearance in microsomes: 2010 mL.min-1.g-1
Compound 4: the middle estimate sits 1.3-fold (0.10 log units) below what was measured; the range from low to high includes it.
By their numbers in this assay, from the lowest: compounds 2, 1, 3 and 4 (each within the scatter of the next, the first and the last beyond it).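

Compound 4 shows that on this aromatic carbon, meta to a large group, this assay does not separate 1,1-difluoroethyl from ethynyl (a 1.1-fold higher number from compound 3 to compound 4 (0.02 log units; within the scatter)), although the entering group holds more heavy atoms and brings in fluorine. The step from the triazole now lies just beyond the scatter (a 2.1-fold higher number from compound 1 to compound 4 (0.33 log units; beyond the scatter)), and the exchange of the whole group on the amide-type nitrogen in a ring stays modest (a 3.1-fold higher number from compound 2 to compound 4 (0.49 log units; beyond the scatter)), but compound 3 and compound 4 lie within the scatter of each other, so the first of these steps should not be over-read. Nothing available here bears on why these numbers fall as they do.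

On these data alone, whether an amine or a carboxylic acid on this aromatic carbon would bring the number nearer to that of compound 2 remains open. A nitrile or a trifluoromethyl in the same place also remains to be placed against compound 3 and compound 4.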